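A few compounds are considered here, and "the series" means these few. Any claim that something is new, unique, unknown or untested is made for them only; others in the source may bear on it.

Series notes. Of the compounds shown here, two have been measured. Compound 1 `O=C(NO)c1cccc(OCc2ccc(-c3ccc(Cl)cc3)cc2)c1` and compound 2 `O=C(NO)c1cccc(OCc2ccc(-c3noc(Cc4ccccc4)n3)cc2)c1` share one core and differ only in the outer group carried on it. In an assay on isolated protein for inhibition of sphingomyelin phosphodiesterase (Homo sapiens), read by fluorescence, with a stated time of 30 min (a lower number here means a stronger inhibitor, a higher number a weaker inhibitor), compound 1 gives 360 nM. In this assay compound 2 gives 4930 nM, the higher of the two numbers; the gap to compound 1 lies beyond the usual scatter, so compound 2 stands as the weaker of the pair.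

Compound 3 `O=C(NO)c1cccc(OCc2ccc(-c3noc(CCc4ccccc4)n3)cc2)c1` is not yet measured. Against compound 2 the change is benzyl in place of phenyl on a saturated chain carbon bound to an aromatic carbon. Going by the values given here, no measured pair isolates this kind of chain lengthening, so there is no measured step to lean on and the only anchor is the value of compound 2. The expected step in this assay is a 1.2-fold lower number from compound 2 to compound 3 (0.09 log units; within the scatter), within the scatter and in no clear direction. Compound 3 is accordingly estimated at 4000 nM, with a range from 1500 nM to 12000 nM.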

Compound 3, half-maximal inhibitory concentration: 4250 nM
Beside the measured number, compound 3's estimate is 1.1-fold (0.03 log units) below it; low and high end bracket the measured number.
By their numbers in this assay, from the lowest: compound 1; then compounds 3 and 2 (each within the scatter of the next).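

In this assay, going by these compounds alone, benzyl in place of phenyl on a saturated chain carbon bound to an aromatic carbon gives a 1.2-fold lower number from compound 2 to compound 3 (0.06 log units; within the scatter), the first measured step for chain lengthening at this position. The same difference, read one bond further out as benzyl to phenethyl, therefore leaves the read-out unresolved in this one pair, and the result cannot be extended to other outer groups on the shared core. Nothing at hand gives a reason for this flat step.

The compounds shown leave open whether a longer chain than phenethyl would also stay within the scatter of compound 3. They also leave open whether an amine or a carboxylic acid on the end of this chain, in place of the terminal phenyl, would shift the number.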